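Removing a Trifluoromethoxy Group in Two Cyclohexane Series

A few compounds are considered here, and "the series" means these few. Any claim that something is new, unique, unknown or untested is made for them only; others in the source may bear on it.

Measured compounds:
compound 1, `COC(=O)C1=C(c2ccc(OC(F)(F)F)cc2)CCCC1`, gives 1660000 nM
compound 2, `COC(=O)C1=C(c2ccccc2)CCCC1`, gives 630000 nM
compound 3, `COC(=O)[C@@H]1CCCC[C@@H]1c1ccc(OC(F)(F)F)cc1`, gives 1180000 nM

All three values come from an assay on COS-1 cells for displacement of a labelled ligand from sodium-dependent dopamine transporter (Homo sapiens); a lower number here means a stronger inhibitor, a higher number a weaker inhibitor. Compound 1 and compound 2 share one core and differ in a single place: hydrogen in place of trifluoromethoxy on an aromatic carbon. That change produced a 2.6-fold lower number from compound 1 to compound 2 (0.42 log units; beyond the scatter). Compound 3 carries a different core from compound 1, and the difference between the two cores is not broken down here; the two compounds give values that lie within the usual scatter of each other, as do compound 3 and compound 2.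

Compound 4, `COC(=O)[C@@H]1CCCC[C@@H]1c1ccccc1`, has not yet been measured in this assay. It is related to compound 3 exactly as compound 2 is related to compound 1: hydrogen in place of trifluoromethoxy on an aromatic carbon. The place of the change is described in the same words for both pairs, so this is the same change made on the second core. Among the measured compounds shown here, with only one earlier example of it, the expectation for compound 4 rests on that single step. For the measured compounds named here, compound 4 is expected to show a 2.6-fold lower number from compound 3 to compound 4 (0.42 log units; beyond the scatter), a step of about the size seen in a 2.6-fold lower number from compound 1 to compound 2 (0.42 log units; beyond the scatter), because a 2.6-fold lower number from compound 1 to compound 2 (0.42 log units; beyond the scatter) is the only guide available. Compound 1 and compound 3 also sit in the same weak range, which supports carrying the step over. On that basis compound 4 is estimated at 450000 nM, with a likely range from 200000 nM to 1000000 nM.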

Compound 4, inhibition constant: 975000 nM
Estimate against measurement, compound 4: 2.2-fold (0.34 log units) below, within the range that was stated.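

In this assay, among the compounds shown here, the replacement of trifluoromethoxy by hydrogen on the second core gave a 1.2-fold lower number from compound 3 to compound 4 (0.08 log units; within the scatter) and so produced no step that stands clear of the usual scatter. For the compounds shown here, this does not show that the change acts differently on the two cores, and it does not show that it acts identically on them either: one step reads beyond the scatter, the other within it, and only two pairs are available to judge from. What the comparison does show is that the two steps cannot be told apart on these data, so carrying the change from one core to the other met no clear contradiction, though it also gained no firm confirmation: the same change on two cores in this assay, a 2.6-fold lower number (0.42 log units; beyond the scatter) from compound 1 to compound 2 and a 1.2-fold lower number (0.08 log units; within the scatter) from compound 3 to compound 4, 2.2-fold (0.34 log units) apart, within the scatter of two such steps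

The compounds shown all carry a methyl ester and have only trifluoromethoxy or hydrogen on the aromatic ring, which leaves open how the same step would read with a carboxylic acid or an amide in place of the ester. Also open, going by these compounds, is whether a chlorine atom or a methoxy group on that same aromatic carbon, or an amine elsewhere on the core, would move the numbers out of this weak range.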